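The source may report more compounds than this note shows. Statements on the series, on what has been measured and on what is new or still open speak of the compounds shown alone.

Of the compounds shown here, three built on one shared core have so far been tested in a functional assay on SW 1116 cells (Homo sapiens) for cytotoxicity, read by MTT assay, with a stated time of 48 h; a lower number here means a stronger inhibitor, a higher number a weaker inhibitor. Compound 1 `O=C(CSc1nnc(-c2ccncc2)o1)N/N=C/c1ccc(O)cc1` gives 12200 nM and stands second highest among the three numbers. Compound 3 `O=C(CSc1nnc(-c2ccncc2)o1)N/N=C/c1cc(Br)ccc1O` gives 8150 nM, and the step of a 1.5-fold lower number from compound 1 to compound 3 (0.18 log units; within the scatter) lies within the scatter. Compound 2 `O=C(CSc1nnc(-c2ccncc2)o1)N/N=C/c1ccccc1[N+](=O)[O-]` gives 30700 nM; the step of a 2.5-fold higher number from compound 1 to compound 2 (0.40 log units; beyond the scatter) is modest, as is the step of a 3.8-fold lower number from compound 2 to compound 3 (0.58 log units; beyond the scatter).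

Compound 4 `O=C(CSc1nnc(-c2ccncc2)o1)N/N=C/c1cc(Br)cc(Br)c1O` has not yet been measured. It differs from compound 1 in one place: 3,5-dibromo-2-hydroxyphenyl in place of 4-hydroxyphenyl on a carbon with a double bond to nitrogen. The step that bears most directly on it is a 1.5-fold lower number from compound 1 to compound 3 (0.18 log units; within the scatter), in which a 5-bromo-2-hydroxyphenyl group entered on a carbon with a double bond to nitrogen and the number barely moved. Compound 4 carries one more bromine on that ring than compound 3, so its number is expected to sit near that of compound 3, with at most a small further lowering. Compound 4 is therefore estimated at 6500 nM, with a range from 3000 nM to 14000 nM. The expected step of a 1.9-fold lower number from compound 1 to compound 4 (0.27 log units; within the scatter) would be modest at most.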

Compound 4, half-maximal inhibitory concentration: 8570 nM
The estimate for compound 4 lay 1.3-fold (0.12 log units) below the measured number; the measured number falls inside the stated range.
By their numbers in this assay, from the lowest: compounds 3, 4 and 1 (each within the scatter of the next); then compound 2.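

In this assay, bromo in place of hydrogen on an aromatic carbon gives a 1.1-fold higher number from compound 3 to compound 4 (0.02 log units; within the scatter) and stays within the scatter, so compounds with one and two bromines on this ring cannot be told apart. The 3,5-dibromo-2-hydroxyphenyl group also stays within the scatter of the 4-hydroxyphenyl group, at a 1.4-fold lower number from compound 1 to compound 4 (0.15 log units; within the scatter) and stands clear of the 2-nitrophenyl group, at a 3.6-fold lower number from compound 2 to compound 4 (0.55 log units; beyond the scatter) as a modest step. No measurement offered here accounts for any of these steps.

The compounds shown leave open whether chloro or methoxy in place of bromo on this ring would give a number beyond the scatter of compound 3. They also do not tell what an amine or a carboxylic acid on this ring would do.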